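Moving the Pyridine Nitrogen in a Cytotoxic Dienone

This account rests on a few compounds, and the source may have more. Where it says the series, first, only, none or still open, it means among the compounds named here.

Two measured compounds share one core and differ in a single halogen. Compound 1 `O=C1/C(=C/c2cccnc2)CN(S(=O)(=O)c2ccc(F)cc2)C/C1=C\c1ccccc1F` gives 15300 nM in a functional assay on QGY-7703 cells (Homo sapiens) for cytotoxicity, read by MTT assay, with a stated time of 24 h; on this read-out higher numbers stand for weaker inhibition and lower numbers for stronger inhibition. Compound 2 `O=C1/C(=C/c2cccnc2)CN(S(=O)(=O)c2ccc(Br)cc2)C/C1=C\c1ccccc1F`, with bromo in place of fluoro on an aromatic carbon, gives 12800 nM in this assay. That step, a 1.2-fold lower number from compound 1 to compound 2 (0.08 log units; within the scatter), lies within the scatter, so the two numbers cannot be told apart. Compound 2 thus stands level with compound 1, with nothing to separate them.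

Compound 3 `O=C1/C(=C/c2ccncc2)CN(S(=O)(=O)c2ccc(Br)cc2)C/C1=C\c1ccccc1F` has not been measured. It keeps the same atoms as compound 2 but joins them differently: pyridin-4-yl in place of pyridin-3-yl on a double-bonded chain carbon bound to a double-bonded ring carbon. The pyridin-4-yl group sits on a double-bonded chain carbon bound to a double-bonded ring carbon, where compound 2 carries pyridin-3-yl.

For the measured compounds named here, no measured step touches that part of the molecule. Going by the values given here, the only step available, a 1.2-fold lower number from compound 1 to compound 2 (0.08 log units; within the scatter), concerns the halogen and is within the scatter. There is thus no ground for expecting a change beyond the scatter in this assay. The expected step of a 1.1-fold lower number from compound 2 to compound 3 (0.03 log units; within the scatter) is a small one. Compound 3 is estimated at 12000 nM in this assay, with a range from 5000 nM to 30000 nM.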

Compound 3, half-maximal inhibitory concentration: 11500 nM
Compound 3: middle estimate off by 1.0-fold (0.02 log units), on the high side; the range from low to high includes it.
By their numbers in this assay, from the lowest: compounds 3, 2 and 1 (each within the scatter of the next).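

Moving the nitrogen within the pyridine ring gives a 1.1-fold lower number from compound 2 to compound 3 (0.05 log units; within the scatter) in this assay, so compound 2 and compound 3 cannot be told apart. For the compounds shown here, the earlier step changed only the halogen, whereas this one shows for the first time that, with the bromo group held fixed, moving the nitrogen within the pyridine ring from the 3-yl to the 4-yl arrangement leaves no readable difference in this cytotoxicity measurement. No measured information on the compounds' properties or behaviour is available to explain this result.

The compounds shown leave open whether pyridin-2-yl or a plain phenyl group at this place would also stay level with compound 2, or whether an amine or a carboxylic acid added to the pyridine ring would produce a change beyond the scatter. They also leave open whether pyridin-4-yl and pyridin-3-yl would remain indistinguishable with fluoro in place of bromo, since this comparison rests on a single pair carrying bromo.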